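The source may report more compounds than this note shows. Statements on the series, on what has been measured and on what is new or still open speak of the compounds shown alone.

Measured so far:
compound 1, `COc1ccc([C@@H]2CC(=O)c3c(O)cc(OCc4cn(C5CCCC5)nn4)cc3O2)cc1O`: 10500 nM
compound 2, `CCCCn1cc(COc2cc(O)c3c(c2)O[C@H](c2ccc(OC)c(O)c2)C/C3=N\O)nn1`: 8900 nM

In a functional assay on RAW264.7 cells (Mus musculus) for inhibition, read by Griess assay, with stated times of 2 h and 24 h (on this read-out lower numbers stand for stronger inhibition and higher numbers for weaker inhibition), compound 1 gives 10500 nM, while compound 2 gives 8900 nM. These two numbers lie within the usual scatter of each other, so nothing separates them on this read-out. Compound 3, `COc1ccc([C@@H]2CC(=O)c3c(O)cc(OCc4cn(Cc5ccccc5Cl)nn4)cc3O2)cc1O`, has not yet been measured; it differs from compound 1 in one place: 2-chlorobenzyl in place of cyclopentyl on an aromatic nitrogen. Among the measured compounds shown here, no measured pair shows what such a change does here, so the step of a 1.2-fold lower number from compound 1 to compound 3 (0.07 log units; within the scatter) is expected to stay within the scatter, in no particular direction. Compound 3 is therefore expected to give about 9000 nM, with a range from 3500 nM to 23000 nM.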

Compound 3, half-maximal inhibitory concentration: 6140 nM
Beside the measured number, compound 3's estimate is 1.5-fold (0.17 log units) above it; the range from low to high includes it.
By their numbers in this assay, from the lowest: compounds 3, 2 and 1 (each within the scatter of the next).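

Among the compounds shown here, putting 2-chlorobenzyl in place of cyclopentyl on this aromatic nitrogen gives the first measured step at this position in this assay: a 1.7-fold lower number from compound 1 to compound 3 (0.23 log units; within the scatter). An aromatic ring can therefore replace a non-aromatic one here with no change that stands out from the scatter. No measured information gives a cause for this result. On these data alone, whether an amine or a carboxylic acid on this nitrogen would move the number beyond the scatter remains open. A plain benzyl group would show what the chlorine contributes.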